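From Isopropylamino to Diethylamino on the Carbonyl Carbon

The compounds below may be only part of what the source reports. "The series", "measured", "known", "first", "only" and "open" are said of these compounds alone.

Compound 1 `CC1=C(C(=O)C2CC2)C(c2cccs2)NC(=O)N1` in an assay on membranes from HEK293 cells for displacement of a labelled ligand from adenosine receptor A2b (Homo sapiens), read by scintillation counting, with a stated time of 30 min, tested at 1 uM; on this read-out lower numbers stand for less inhibition and higher numbers for more inhibition at the one concentration tested (going by the name of the read-out): 1%
Compound 2 `CC1=C(C(=O)NC(C)C)C(c2cccs2)NC(=O)N1` in this assay: 40%

Compound 2 stands highest of the two numbers, and the step of a number 39 percentage points higher from compound 1 to compound 2 (beyond the scatter) shows that the group on the carbonyl carbon matters greatly here. Compound 3 `CCN(CC)C(=O)C1=C(C)NC(=O)NC1c1cccs1` differs from compound 2 by diethylamino in place of isopropylamino on a carbonyl carbon. For the measured compounds named here, only that one measured step bears on this position, and it was large, so a sizeable shift in this assay is plausible, but its direction is not fixed by the data. Compound 3 is estimated to fall somewhat lower, with a number 20 percentage points lower from compound 2 to compound 3 (beyond the scatter), giving about 20% within 0% to 45%.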

Compound 3, a percentage reported as inhibition, at one concentration (the size of the read-out at that concentration, not a potency): 22%
The estimate for compound 3 lay 2 percentage points below the measured number, within the range that was stated.
By their numbers in this assay, from the lowest: compound 1; then compound 3; then compound 2.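

Replacing isopropylamino with diethylamino gives a number 18 percentage points lower from compound 2 to compound 3 (beyond the scatter) in this assay, so two amine groups on this carbonyl carbon are not interchangeable. Diethylamino still stands clear of cyclopropyl, with a number 21 percentage points higher from compound 1 to compound 3 (beyond the scatter), so compound 3 keeps part of the gain seen with compound 2. Nothing measured here explains these differences. The change both removes a hydrogen-bond donor and adds a carbon, and these compounds cannot separate the two. Going by these compounds, how dimethylamino or a ring amine such as piperidine would behave on this carbonyl carbon also remains open.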